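This account rests on a few compounds, and the source may have more. Where it says the series, first, only, none or still open, it means among the compounds named here.

Compound 3 `CCCCCCCC(=O)OCc1ccc(O)c(OC)c1` is the reference point for the step followed here. In a functional assay on the whole organism (strain KM) with Mus musculus as the target, in the writhing test, with a stated time of 30 min (a lower number here means that less compound is needed, a higher number that more compound is needed for the effect), compound 3 gives 12.6 mg/kg, the highest of the three numbers measured: compound 2 `CCCCCCCCCC(=O)OCc1ccc(OCCCC)c(OC)c1` gives 3.16 mg/kg, and compound 1 `CCCCCCCCCC(=O)OCc1ccc(OCCCCCC)c(OC)c1` gives 1.84 mg/kg. Compound 4 `CCCCCCCCCCCC(=O)OCc1ccc(O)c(OC)c1` has not been measured. It differs from compound 3 by butyl in place of hydrogen on a saturated chain carbon, seven bonds along the chain from a carbonyl carbon. Among the measured compounds shown here, no measured step touches that part of the molecule; the only step at hand, a 1.7-fold higher number from compound 1 to compound 2 (0.23 log units; within the scatter), concerns the chain on the aromatic oxygen and lies within the scatter. Chain lengthening of that kind thus carried no clear effect, so for compound 4 in this assay no change beyond the scatter is expected, and its value is estimated at 10 mg/kg with a range from 4 mg/kg to 25 mg/kg, meaning an expected step of a 1.3-fold lower number from compound 3 to compound 4 (0.10 log units; within the scatter).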

Compound 4, dose for half-maximal effect: 19.4 mg/kg
Beside the measured number, compound 4's estimate is 1.9-fold (0.29 log units) below it; the measured number falls inside the stated range.
By their numbers in this assay, from the lowest: compounds 1 and 2 (each within the scatter of the next); then compounds 3 and 4 (each within the scatter of the next).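

In this assay, among the compounds shown here, butyl in place of hydrogen on a saturated chain carbon, seven bonds along the chain from a carbonyl carbon, gives a 1.5-fold higher number from compound 3 to compound 4 (0.19 log units; within the scatter) as the first measured step at this position. The chain here thus takes on butyl with no change beyond the scatter, which a 1.7-fold higher number from compound 1 to compound 2 (0.23 log units; within the scatter) had shown only for the chain on the aromatic oxygen. Nothing at hand bears on the cause of this result. Still open, going by these compounds, is whether a longer chain at this position, or an amine or a carboxylic acid at its end, would move the number beyond the scatter.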